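Swapping the aryl group on the triazole benzyl position

A few compounds are considered here, and "the series" means these few. Any claim that something is new, unique, unknown or untested is made for them only; others in the source may bear on it.

Compound 1 `COc1cc(OC)c(Cn2cc(CN(Cc3cn(S(=O)(=O)c4ccc(C)cc4)c4ccccc34)S(=O)(=O)c3ccc(C)cc3)nn2)c(OC)c1`: -22%
Compound 2 `Cc1ccc(S(=O)(=O)N(Cc2cn(Cc3cccc(F)c3F)nn2)Cc2cn(S(=O)(=O)c3ccc(C)cc3)c3ccccc23)cc1`: 71.5%

Compound 2 stands highest of the two measured numbers in a functional assay on 3T3-L1 cells (Mus musculus) for inhibition, with a stated time of 20 min, tested at 20 uM; a higher number here means more inhibition at the concentration tested (going by the name of the read-out), a lower number less inhibition; its nearest neighbour is compound 1, a number far lower. Compound 3 `COc1ccc(Cn2cc(CN(Cc3cn(S(=O)(=O)c4ccc(C)cc4)c4ccccc34)S(=O)(=O)c3ccc(C)cc3)nn2)cc1` has not yet been measured. It differs from compound 2 in one place: 4-methoxyphenyl in place of 2,3-difluorophenyl on a saturated chain carbon bound to an aromatic nitrogen. Going by the values given here, the one measured step that bears on this is a number 93.5 percentage points higher from compound 1 to compound 2 (beyond the scatter), which shows that the aryl group on this saturated chain carbon bound to an aromatic nitrogen can move this assay by a large amount. Compound 3 carries one methoxy group where compound 1 carried three, so a step back toward the number of compound 1 is expected, though of unknown size. The expected step is a number 41.5 percentage points lower from compound 2 to compound 3 (beyond the scatter), downward and beyond the scatter. For compound 3 the estimate in this assay is 30%, within a range from -5% to 62%.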

Compound 3, a percentage reported as inhibition, at one concentration (the size of the read-out at that concentration, not a potency): 1%
Compound 3: middle estimate off by 29 percentage points, on the high side, and the stated range covers the measured number.
By their numbers in this assay, from the lowest: compound 1; then compound 3; then compound 2.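

In this assay, putting 4-methoxyphenyl in place of 2,3-difluorophenyl on the saturated chain carbon bound to an aromatic nitrogen gives a number 70.5 percentage points lower from compound 2 to compound 3 (beyond the scatter) and so removes most of the inhibition seen with compound 2. Going the other way, replacing 2,4,6-trimethoxyphenyl with 4-methoxyphenyl gives a number 23 percentage points higher from compound 1 to compound 3 (beyond the scatter) as a modest step, which leaves compound 3 much nearer to compound 1 than to compound 2. Among these three compounds, then, both methoxy-bearing rings sit low and only the 2,3-difluorophenyl ring reaches a high number, and cutting the methoxy groups from three to one recovers only a small part of that gap.

Still open, going by these compounds, is whether the high number follows the two fluorines or simply the lack of any methoxy group, a question that a plain phenyl or a 4-chlorophenyl group at this position would bear on. Nothing available here explains why these aryl groups differ so widely.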